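Fluoro on the Fused Ring: Cytotoxicity of Compound 4

The source may report more compounds than this note shows. Statements on the series, on what has been measured and on what is new or still open speak of the compounds shown alone.

Three compounds share a core in which a hydroxylated, methyl-bearing ring carries a short arm ending in a nitrogen attached to an aromatic group. Compound 1, `CC1(C)C[C@H](O)C[C@](C)(CNC(=O)c2ccccc2O)C1`, carries a hydroxybenzamide on that arm. Compound 2, `CC1(C)C[C@H](O)C[C@](C)(CNc2ncc3ccccc3n2)C1`, carries a fused two-ring aromatic group containing nitrogen. Compound 3, `CC1(C)C[C@H](O)C[C@](C)(CNc2nc3ccccc3s2)C1`, carries a fused two-ring aromatic group containing nitrogen and sulfur.

All three were tested in an ADME assay on MDCK cells (Canis lupus familiaris) for cytotoxicity, read by MTT assay, with a stated time of 3 days; on this read-out higher numbers stand for lower toxicity in this test and lower numbers for higher toxicity in this test. Compound 1 gives no number there but only a limit, > 50000 nM, which is the limit of > 50000 nM in this assay, at which 1 of the 3 values shown sits. Compound 2 gives 26700 nM. Compound 3 gives 36800 nM, and its gap to compound 2 lies within the scatter of this assay, so the two are not distinguished by these numbers.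

Compound 4, `CC1(C)C[C@H](O)C[C@](C)(CNc2nc3ccc(F)cc3s2)C1`, differs from compound 3 in one place: fluoro in place of hydrogen on an aromatic carbon. Among the compounds with values here, a single fluorine in place of a hydrogen is a small change, and no measured step here tells what such a change does. The expected step from compound 3 to compound 4 is therefore a 1.1-fold lower number from compound 3 to compound 4 (0.02 log units; within the scatter), which is none beyond the scatter in either direction. Compound 4 is estimated at 35000 nM, between 15000 nM and 70000 nM.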

Compound 4, half-maximal cytotoxic concentration: 16200 nM
Compound 4: the middle estimate sits 2.2-fold (0.33 log units) above what was measured, and the stated range covers the measured number.
By their numbers in this assay, from the lowest: compounds 4, 2 and 3 (each within the scatter of the next, the first and the last beyond it). At a limit, above all of these: compound 1.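

Within the data shown here, this is the first measured step that changes one place only. In this assay, fluoro in place of hydrogen on an aromatic carbon gives a 2.3-fold lower number from compound 3 to compound 4 (0.36 log units; beyond the scatter), a modest step, but one that stands clear of the usual variation between repeated measurements. Lower numbers on this read-out stand for higher toxicity in this test, so at this position, on the six-membered aromatic ring of carbon only within the fused system, one added fluorine is enough to shift the result towards greater toxicity, though nothing shown here explains why the number fell.

Still open, on these data alone, is whether this position responds only to fluoro or also to other groups, such as chloro, methoxy, an amine or a carboxylic acid, and whether any of these would move the number in the same direction. As far as these compounds go, it is equally open whether fluoro on another carbon of the same ring, or on the fused two-ring group of compound 2, would give a step of similar size.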